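Ethyl to Methoxymethyl on the Aromatic Ring

The compounds below may be only part of what the source reports. "The series", "measured", "known", "first", "only" and "open" are said of these compounds alone.

Two measured compounds frame this step. In an assay on CHO cells for displacement of a labelled ligand from prostaglandin E2 receptor EP4 subtype (Mus musculus), read by scintillation counting, with a stated time of 60 min (a lower number here means a stronger inhibitor, a higher number a weaker inhibitor), compound 1 `O=C(O)CCCSCCN1C(=O)OC[C@@H]1/C=C/[C@@H](O)Cc1cccc(-c2ccccc2)c1` gives 28 nM. In this assay compound 2 `CCc1cccc(C[C@H](O)/C=C/[C@H]2COC(=O)N2CCSCCCC(=O)O)c1` gives 7.9 nM, the lowest of the two numbers, reached by the step of a 3.5-fold lower number from compound 1 to compound 2 (0.55 log units; beyond the scatter). Compound 3 `COCc1cccc(C[C@H](O)/C=C/[C@H]2COC(=O)N2CCSCCCC(=O)O)c1` is not yet measured and differs from compound 2 by methoxy in place of methyl on a saturated chain carbon bound to an aromatic carbon. Among the compounds with values here, no measured pair shows exactly this change; the single measured step, a 3.5-fold lower number from compound 1 to compound 2 (0.55 log units; beyond the scatter), concerns another group on the same ring and only suggests that changes in this part of the molecule have so far shifted the number modestly. A modest step in either direction, or none beyond the scatter, is therefore expected, with the added hydrogen-bond acceptor untested so far. For compound 3 the estimate is 12 nM, with a range from 4 nM to 40 nM. The expected step is a 1.5-fold higher number from compound 2 to compound 3 (0.18 log units; within the scatter).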

Compound 3, inhibition constant: 7.2 nM
Estimate against measurement, compound 3: 1.7-fold (0.22 log units) above, within the range that was stated.
By their numbers in this assay, from the lowest: compounds 3 and 2 (each within the scatter of the next); then compound 1.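

In this assay, exchanging ethyl for methoxymethyl gives a 1.1-fold lower number from compound 2 to compound 3 (0.04 log units; within the scatter), so at this position the oxygen and its hydrogen-bond acceptor, new to the series, bring no shift that can be told from the scatter. Methoxymethyl in place of phenyl on an aromatic carbon gives a 3.9-fold lower number from compound 1 to compound 3 (0.59 log units; beyond the scatter), so a second small group, alongside ethyl, now gives a lower number than phenyl, and that step lies beyond the scatter. Nothing available explains why the added oxygen leaves the number within the scatter.

Still open, as far as these compounds go, is whether a hydroxymethyl or an aminomethyl group, which would replace the methoxy end of the chain, would also stay within the scatter of compound 2. The compounds shown also leave open how far this chain can grow, for instance to ethoxymethyl, before the number moves.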